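The source may report more compounds than this note shows. Statements on the series, on what has been measured and on what is new or still open speak of the compounds shown alone.

Measured compounds:
- compound 1 `O=C1NCCN1c1ccc(S(=O)(=O)Nc2ccc3[nH]ccc3c2)cc1`: in a functional assay on M21 cells (Homo sapiens) for antiproliferative activity, read by sulforhodamine B assay, with a stated time of 48 h (on this read-out lower numbers stand for stronger inhibition and higher numbers for weaker inhibition), compound 1 gives 87 nM
- compound 2 `Cc1ccc(NS(=O)(=O)c2ccc(N3CCNC3=O)cc2)cc1C`: in this assay compound 2 gives 94 nM
- compound 3 `COc1ccc(NS(=O)(=O)c2ccc(N3CCNC3=O)cc2)cc1OC`: in this assay compound 3 gives 340 nM

All three share the same core and differ only in the aromatic group that sits on the sulfonamide nitrogen. Compound 2 stands second highest of the three numbers. Its nearest neighbour is compound 1, whose number lies within the usual scatter of compound 2, so the two cannot be told apart. Compound 3 is the furthest away, with a number beyond the scatter on the higher side, which means weaker inhibition.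

Compound 4 `Cc1ccc(NS(=O)(=O)c2ccc(N3CCNC3=O)cc2)c(C)c1` has not yet been measured. Compared with compound 2 it carries 2,4-dimethylphenyl in place of 3,4-dimethylphenyl on a sulfonamide nitrogen; the two have the same atoms, joined differently. Among the compounds with values here, no pair of measured compounds differs in just this way, so the size of this step has no anchor in the data. Moving a methyl around a ring of this kind is usually a small change, and the expectation is a step at or near the edge of the scatter, leaning slightly toward a higher number. In this assay compound 4 is estimated at 180 nM, with a likely range from 60 nM to 600 nM. The estimated step of a 1.9-fold higher number from compound 2 to compound 4 (0.28 log units; within the scatter) is expected to be modest.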

Compound 4, half-maximal inhibitory concentration: 150 nM
Compound 4: middle estimate off by 1.2-fold (0.08 log units), on the high side; the range from low to high includes it.
By their numbers in this assay, from the lowest: compounds 1, 2 and 4 (each within the scatter of the next); then compound 3.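

Placing 2,4-dimethylphenyl in place of 3,4-dimethylphenyl on a sulfonamide nitrogen provides the first comparison in this set where only one place differs, and in this assay it gives a 1.6-fold higher number from compound 2 to compound 4 (0.20 log units; within the scatter) between the two compounds. The two cannot be told apart here, so for this pair, rearranging the same two methyl groups on the ring leaves the read-out within what repeat measurements would be expected to show. The change keeps every counted feature of the group the same, so this pair isolates the arrangement of the methyl groups alone, and that arrangement has no effect that can be resolved in this assay. No measurement shown here offers an explanation for this result.

Going by these compounds, whether this position accepts other groups just as readily remains open, for example a chlorine atom, an amine or a carboxylic acid on the ring in place of a methyl. Also unresolved is how a phenyl ring carrying only a single methyl would compare with these two dimethylphenyl compounds.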